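Moving a Chlorine Around the Benzyl Ring

This account rests on a few compounds, and the source may have more. Where it says the series, first, only, none or still open, it means among the compounds named here.

Compound 1 `COc1ccc(C2N=C(SCc3cccc(Cl)c3)NC(C)=C2C(=O)Nc2ccc(F)cc2)cc1OC`, compound 2 `COc1ccc(C2N=C(SCc3ccc(Cl)cc3)NC(C)=C2C(=O)Nc2ccc(F)cc2)cc1OC` and compound 3 `COc1ccc(C2N=C(SCc3cccc(Cl)c3)NC(C)=C2C(=O)Nc2ccc(Br)cc2)cc1` were tested in a functional assay on the whole organism (artery, strain albino) with Rattus norvegicus as the target, with a stated time of 900 min, at a dose of 10 mg/kg by the oral route; a higher number here means more inhibition at the dose given (going by the name of the read-out), a lower number less inhibition. There compound 1 gives 13.3%, compound 2 gives 20% and compound 3 gives 22.6%. Compound 2 differs from compound 1 by 4-chlorophenyl in place of 3-chlorophenyl on a saturated chain carbon bound to a sulfur, and this change made a number 6.7 percentage points higher from compound 1 to compound 2 (within the scatter). The difference between the cores of compound 1 and compound 3 is not broken down here. Compound 4 `COc1ccc(C2N=C(SCc3ccc(Cl)cc3)NC(C)=C2C(=O)Nc2ccc(Br)cc2)cc1` has not yet been measured; it differs from compound 3 by 4-chlorophenyl in place of 3-chlorophenyl on a saturated chain carbon bound to a sulfur, the same change at the same place. Because compound 1 to compound 2 gave a number 6.7 percentage points higher from compound 1 to compound 2 (within the scatter), the expected step is a number 6.4 percentage points higher from compound 3 to compound 4 (within the scatter). Compound 4 is therefore estimated at 29%, between 15% and 42%.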

Compound 4, a percentage reported as inhibition, in the whole organism at one dose (the size of the read-out at that dose, not a potency): 20%
Compound 4: the middle estimate sits 9 percentage points above what was measured; the range from low to high includes it.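

In this assay, 4-chlorophenyl in place of 3-chlorophenyl gave a number 2.6 percentage points lower from compound 3 to compound 4 (within the scatter). Set beside the earlier step, the result does not separate the two cores: the same change on two cores in this assay, a number 6.7 percentage points higher (within the scatter) from compound 1 to compound 2 and a number 2.6 percentage points lower (within the scatter) from compound 3 to compound 4, 9.3 percentage points apart, within the scatter of two such steps. Nothing here shows that the change behaves differently on the two cores, but since each step lies within the scatter, it also does not show that the change has a real effect that carries from one core to the other.

The compounds shown leave open whether a larger step would come from replacing the chlorine with a nitrile or a carboxylic acid. The same question stands for a longer chain on the sulfur in place of the chlorobenzyl group.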